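A Butylsulfanyl Chain in Place of the Piperidine Ring

The source may hold more compounds than are shown below. What is called first, only, known or untested is meant among the compounds shown, and "the series" means these compounds.

Compound 1 `CC1CCN(c2cc(C(F)(F)F)ccc2CNC(=O)C(C)c2ccc(NS(C)(=O)=O)c(F)c2)CC1` is examined in an assay on CHO cells for antagonist activity at transient receptor potential cation channel subfamily V member 1 (Homo sapiens), read by FLIPR (a higher number here means a weaker inhibitor, a lower number a stronger inhibitor), where compound 1 gives 0.9 nM. Two other compounds share its core. Compound 2 `Cc1cccc(N2CCN(c3cc(C(F)(F)F)ccc3CNC(=O)C(C)c3ccc(NS(C)(=O)=O)c(F)c3)CC2)c1` gives 1.8 nM in this assay, and compound 3 `CCCCCCOc1cc(C(C)(F)F)ccc1CNC(=O)C(C)c1ccc(NS(C)(=O)=O)c(F)c1` gives 0.8 nM in this assay. Among these three numbers compound 1 stands second highest, yet its number lies within the usual scatter of both compound 3 and compound 2, so no order or change between the three can be read from them.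

Compound 4 `CCCCSc1cc(C(F)(F)F)ccc1CNC(=O)C(C)c1ccc(NS(C)(=O)=O)c(F)c1` has not yet been measured. It differs from compound 1 in a single place: butylsulfanyl in place of 4-methylpiperidin-1-yl on an aromatic carbon. Going by the values given here, no step between measured compounds that differ in one place is available to guide the expectation; the account rests on the three values given, which all sit close together. A step in this assay that stays within the scatter is therefore expected, with a slight lean toward a higher number.

Compound 4 is expected to give 1.5 nM in this assay, with a range from 0.5 nM to 5 nM. This estimate amounts to a step of a 1.7-fold higher number from compound 1 to compound 4 (0.22 log units; within the scatter), which is expected to remain within the scatter.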

Compound 4, inhibition constant: 1.9 nM
Estimate against measurement, compound 4: 1.3-fold (0.10 log units) below; measured number inside the range.
By their numbers in this assay, from the lowest: compounds 3, 1, 2 and 4 (each within the scatter of the next, the first and the last beyond it).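

In this assay, butylsulfanyl in place of 4-methylpiperidin-1-yl gives a 2.1-fold higher number from compound 1 to compound 4 (0.32 log units; beyond the scatter), the only step shown that isolates a change at this aromatic carbon, ortho to a large group and meta to a trifluoromethyl group. The step is modest: an open chain carrying sulfur can replace the nitrogen-linked six-membered ring here, and compound 4 still gives 1.9 nM. No measurement shown explains this step.

Because the ring, the linking atom and the chain all change together, the step cannot be assigned to any one of them. On these data alone, a butylamino or butoxy chain on this carbon, or a longer chain on the sulfur such as hexylsulfanyl, would help separate these contributions, and their effect remains open.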